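The source may hold more compounds than are shown below. What is called first, only, known or untested is meant among the compounds shown, and "the series" means these compounds.

Compounds measured so far in an assay on RPMI-8226 cells for antagonist activity at P2X purinoceptor 7 (Homo sapiens), read by calcium flux; a higher number here means a weaker inhibitor, a lower number a stronger inhibitor:

Compound 1, `Cc1nc2ccccc2n1CCCCN1CCN(C(c2ccccc2)c2ccccc2)CC1`: 850 nM
Compound 2, `c1ccc(-c2nc3ccccc3n2CCCCN2CCN(C(c3ccccc3)c3ccccc3)CC2)cc1`: 1200 nM

Going by the values given here, compound 1 gives the lowest of the two numbers in this assay, and its nearest neighbour is compound 2; the single measured step, a 1.4-fold higher number from compound 1 to compound 2 (0.15 log units; within the scatter), is within the scatter, so the two cannot be ordered. That step exchanges phenyl for methyl on an aromatic carbon and leaves the rest of the molecule untouched.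

The unmeasured compound 3, `COc1ccc2c(ccn2CCCCN2CCN(C(c3ccccc3)c3ccccc3)CC2)c1`, differs from compound 1 in another way: 5-methoxy-1H-indol-1-yl in place of 2-methyl-1H-benzimidazol-1-yl on a saturated chain carbon, four bonds along the chain from an amine nitrogen in a ring. Among the compounds with values here, no measured step exchanges the whole ring system at that position, so the step from compound 1 to compound 2 bears on it only loosely, as a sign that a change at the end of the chain has so far moved the number by little. On that basis a step of modest size in this assay is expected, with no clear direction, and most likely not far beyond the scatter.

Compound 3 is therefore estimated at 1200 nM, in a range from 400 nM to 4000 nM. This estimate means an expected step of a 1.4-fold higher number from compound 1 to compound 3 (0.15 log units; within the scatter).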

Compound 3, half-maximal inhibitory concentration: > 10000 nM
Compound 3: a limit, no number; the forecaster's own chance of this, stated with the estimate: 10%; middle value at least 8.3-fold (0.92 log units) from the limit.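

In this assay, the exchange of 2-methyl-1H-benzimidazol-1-yl for 5-methoxy-1H-indol-1-yl gives an at least 11-fold higher number from compound 1 to compound 3 (1.07 log units; beyond the scatter), so the group on this saturated chain carbon, four bonds along the chain from an amine nitrogen in a ring, can matter a great deal. The reading for compound 3 is a limit of the assay and not a number: the limit of > 10000 nM in this assay, at which 1 of the 3 values shown sits. Going by these compounds alone, the only earlier step at the end of the chain, phenyl in place of methyl on an aromatic carbon, stayed within the scatter, so compound 3 is the first compound to show that a change in this part of the molecule can carry a large penalty.

This one exchange alters the ring nitrogen, removes the methyl and adds the methoxy all at once, and the compounds shown cannot say which of these carries the loss. Going by these compounds, a plain 1H-indol-1-yl group or a 2-methyl-1H-indol-1-yl group at the same place would separate these changes, and how far the number for compound 3 really lies past its limit remains open.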